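The source may hold more compounds than are shown below. What is called first, only, known or untested is meant among the compounds shown, and "the series" means these compounds.

Compound 1 `CC(=O)Oc1ccc(C(=O)Nc2cc3ccc(OCCC4CCCCN4)c(C)c3oc2=O)cc1CC=C(C)C` and compound 2 `CC(=O)Oc1ccc(C(=O)Nc2cc3ccc(OCC4CCCNC4)c(C)c3oc2=O)cc1CC=C(C)C` share their core with compound 3 `CCN(CC)CCCOc1ccc2cc(NC(=O)c3ccc(O)c(CC=C(C)C)c3)c(=O)oc2c1C` and differ from it in the chain that carries the amine and in the group on the outer ring. In a functional assay on SK-BR-3 cells (Homo sapiens) for antiproliferative activity (on this read-out lower numbers stand for stronger inhibition and higher numbers for weaker inhibition), compound 1 gives 640 nM, compound 2 gives 620 nM and compound 3 gives 4900 nM. Within the data shown here, the only step that changes a single place is a 1.0-fold lower number from compound 1 to compound 2 (0.01 log units; within the scatter). Compound 3 has the highest number of the three, and both gaps to it lie beyond the scatter, so compound 3 is the weakest inhibitor of the measured set.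

Compound 4 `CC(C)=CCc1cc(C(=O)Nc2cc3ccc(OCCCNCC(=O)O)c(C)c3oc2=O)ccc1O` differs from compound 3 in one place: (carboxymethyl)amino in place of diethylamino on a saturated chain carbon, three bonds along the chain from an oxygen on an aromatic ring. Among the measured compounds shown here, no measured step swaps an open-chain amine for an amine that carries a carboxymethyl group, so there is no direct precedent. For the measured compounds named here, the one step that does alter the amine-bearing chain, from compound 1 to compound 2, left the number essentially unchanged. Compounds 1 and 2 sit far below compound 3, but they also differ from compound 3 elsewhere, so their values cannot be laid to the amine alone.

The expectation for compound 4 is therefore only loosely anchored, and a step of a 1.4-fold lower number from compound 3 to compound 4 (0.15 log units; within the scatter) is estimated. Compound 4 is expected near 3500 nM, within a range from 900 nM to 14000 nM.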

Compound 4, half-maximal inhibitory concentration: 7570 nM
Beside the measured number, compound 4's estimate is 2.2-fold (0.34 log units) below it; low and high end bracket the measured number.
By their numbers in this assay, from the lowest: compounds 2 and 1 (each within the scatter of the next); then compounds 3 and 4 (each within the scatter of the next).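

Among these compounds, this is the first direct reading of the amine at the end of the three-carbon chain, with the rest of compound 3 held fixed. In this assay, putting (carboxymethyl)amino in place of diethylamino gives a 1.5-fold higher number from compound 3 to compound 4 (0.19 log units; within the scatter), so compound 3 and compound 4 cannot be told apart on this read-out. The two groups have the same number of heavy atoms, but the entering one trades two of the carbons for oxygens and adds hydrogen-bond donors that diethylamino lacks, so this position accepted a clear change in the make-up of the group without a separable difference in the cell read-out, and nothing at hand explains that outcome.

One exchange cannot show whether this holds for other groups at this place, such as a morpholine, a methyl ester of the carboxylic acid, or the same amine on a longer chain. It also leaves open whether (carboxymethyl)amino would behave the same way on the piperidine-bearing compounds, whose outer ring carries a different group.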